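A few compounds are considered here, and "the series" means these few. Any claim that something is new, unique, unknown or untested is made for them only; others in the source may bear on it.

In a functional assay on HT29-AK cells (Homo sapiens) for cytotoxicity, read by MTT assay, with a stated time of 48 h (on this read-out higher numbers stand for weaker inhibition and lower numbers for stronger inhibition), the measured compounds are:

- Compound 1 `Fc1cccc(-c2nc(Nc3cccc(Cl)c3)c3cc(F)ccc3n2)c1` gives > 50000 nM as a limit
- Compound 2 `Fc1cccc(-c2nc(Nc3cccc(Br)c3)c3cc(F)ccc3n2)c1` gives > 50000 nM as a limit
- Compound 3 `Cc1cccc(Nc2nc(-c3cccc(F)c3)nc3ccc(F)cc23)c1` gives > 50000 nM as a limit

Compound 3 has no exact number and stands with the other two at the limit of > 50000 nM in this assay, at which 3 of the 3 values shown sit, on this scale.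

The next compound, compound 4 `Cc1ccccc1Nc1nc(-c2cccc(F)c2)nc2ccc(F)cc12`, has the same atoms joined differently: 2-methylphenyl in place of 3-methylphenyl on a nitrogen on an aromatic ring. In words, this is 2-methylphenyl in place of 3-methylphenyl on a nitrogen on an aromatic ring.

The closest evidence comes from the measured swaps of a single group. However, a step that the two limits leave unreadable from compound 1 to compound 3, a step that the two limits leave unreadable from compound 2 to compound 3 and a step that the two limits leave unreadable from compound 1 to compound 2 all offer no size to carry over, and none of them tests this change directly. With nothing pointing either way, no step beyond the scatter is expected, and compound 4 will most likely also be reported only as a limit. The expected result is a number no higher from compound 3 to compound 4 (the limit leaves the size open) in this assay as an estimate with no preferred direction. For compound 4 the estimate is 50000 nM with 20000 nM to 100000 nM as the expected range.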

Compound 4, half-maximal inhibitory concentration: > 50000 nM
Compound 4 was reported as a limit; the forecaster's own chance of this, stated with the estimate: 85%; the middle value sits exactly at the limit.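

No step can be read between compound 4 and compound 1, compound 2 or compound 3, because each result is only a limit: the limit of > 50000 nM in this assay, at which 4 of the 4 values shown sit.

How strongly any of these compounds acts on the cells, and whether changing the group on the nitrogen matters at all, stays open.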